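From compound 3 to compound 4: a step without a baseline

The compounds below may be only part of what the source reports. "The series", "measured", "known", "first", "only" and "open" are said of these compounds alone.

In a functional assay on PC-3 cells (Homo sapiens) for antiproliferative activity, read by MTT assay, with a stated time of 72 h (on this read-out higher numbers stand for weaker inhibition and lower numbers for stronger inhibition), compound 1 `O=C(N/N=C/c1ccc(Br)cc1)Nc1ccc(Oc2ccnc3[nH]ccc23)c(F)c1` gives 920 nM as its value and compound 2 `O=C(N/N=C/c1ccc([N+](=O)[O-])cc1)Nc1ccc(Oc2ccnc3[nH]ccc23)c(F)c1` gives 150 nM as its value. Compound 3 `O=C(N/N=C/c1cccc(Cl)c1Cl)Nc1ccc(Oc2ccnc3[nH]ccc23)c(F)c1` is reported as "not active" (no number reported) and has no place on the numeric scale. Compound 4 `O=C(N/N=C/c1ccc(O)c(Br)c1)Nc1ccc(Oc2ccnc3[nH]ccc23)c(F)c1` carries 3-bromo-4-hydroxyphenyl in place of 2,3-dichlorophenyl. Its difference from compound 3 is 3-bromo-4-hydroxyphenyl in place of 2,3-dichlorophenyl on a carbon with a double bond to nitrogen. For the measured compounds named here, the sole measured step, a 6.1-fold lower number from compound 1 to compound 2 (0.79 log units; beyond the scatter) for nitro in place of bromo, is modest and does not cover this change. No step size can be derived from compound 3, so only a move from no number to a measurable one is expected, and this is uncertain. Compound 4 is expected near 900 nM with an estimated range from 200 nM to 5000 nM in this assay as a working figure.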

Compound 4, half-maximal inhibitory concentration: 28600 nM
Estimate against measurement, compound 4: 32-fold (1.50 log units) below; measured number outside the range, above it.
By their numbers in this assay, from the lowest: compound 2; then compound 1; then compound 4.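

In this assay, the group on the carbon with a double bond to nitrogen moves the number much further than the earlier nitro-for-bromo step did (a 190-fold higher number from compound 2 to compound 4 (2.28 log units; beyond the scatter)) and (a 31-fold higher number from compound 1 to compound 4 (1.49 log units; beyond the scatter)). 3-bromo-4-hydroxyphenyl gives a measurable number, unlike the 2,3-dichlorophenyl of compound 3, but a bromine on this ring does not by itself keep compound 4 close to compound 1. No supporting data bear on the size of these steps.

Open, going by these compounds, is whether a methoxy group or an amine in place of the hydroxyl would bring the number back toward compound 2.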